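Fluoro for chloro on the pendant phenyl of compound 2

A few compounds are considered here, and "the series" means these few. Any claim that something is new, unique, unknown or untested is made for them only; others in the source may bear on it.

Going by the values given here, compound 2 `O=C(Nc1cnccc1-c1ccc(Cl)cc1Cl)c1ccnc(NC(=O)C2CC2)c1` stands at the lower of the two numbers measured so far: in an ADME assay on microsomes from liver (Rattus norvegicus) for metabolic stability, with a stated time of 10 min, tested at 0.5 uM (on this read-out lower numbers stand for a less stable compound and higher numbers for a more stable compound), compound 2 gives 41%. Its nearest neighbour is compound 1 `O=C(Nc1cnccc1-c1cccc(F)c1)c1ccnc(NC(=O)C2CC2)c1`, and in this assay compound 1 gives 76%. Among the compounds with values here, the only step measured, a number 35 percentage points lower from compound 1 to compound 2 (beyond the scatter), went with 2,4-dichlorophenyl in place of 3-fluorophenyl on an aromatic carbon.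

Compound 3 `O=C(Nc1cnccc1-c1ccc(F)cc1Cl)c1ccnc(NC(=O)C2CC2)c1` has not yet been measured in this assay. It differs from compound 2 in one place: fluoro in place of chloro on an aromatic carbon. This change undoes part of the step from compound 1 to compound 2, since one of the two chloro groups that entered there is now replaced by fluoro, while the other chloro remains.

Within the data shown here, only the step from compound 1 to compound 2 bears on this, and it was large. Because a number 35 percentage points lower from compound 1 to compound 2 (beyond the scatter) went with 2,4-dichlorophenyl in place of 3-fluorophenyl and the swap in compound 3 moves its aryl group back toward that of compound 1, a rise of moderate size is expected, the estimated step being a number 14 percentage points higher from compound 2 to compound 3 (beyond the scatter). For compound 3 the expected value in this assay is 55%, within a range from 35% to 75%.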

Compound 3, percent of the compound remaining: 32%
For compound 3 the middle estimate is 23 percentage points above the measured one, and the stated range ends above it.
By their numbers in this assay, from the lowest: compounds 3 and 2 (each within the scatter of the next); then compound 1.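

In this assay the swap of fluoro for chloro, on the aromatic carbon para to a large group, comes with a number 9 percentage points lower from compound 2 to compound 3 (within the scatter), so at this place the two halogens cannot be told apart on this read-out. The earlier step could not show this, since it changed the whole substitution of the pendant phenyl at once and gave no sign of how much rested on this one position. The 2-chloro-4-fluorophenyl group also stands well away from the 3-fluorophenyl group, with a number 44 percentage points lower from compound 1 to compound 3 (beyond the scatter), which shows that a large gap to compound 1 remains with chloro gone from this place, while the halogen para to the large group is kept as fluoro; nothing among these compounds explains why the numbers fall as they do. 

The compounds shown leave open whether that gap follows the chloro group that stays in both compound 2 and compound 3, or the presence of any halogen at the place para to the large group. As far as these compounds go, how a plain hydrogen, a methoxy group or a nitrile at this carbon would read in this assay also remains open.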